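The source may hold more compounds than are shown below. What is called first, only, known or untested is meant among the compounds shown, and "the series" means these compounds.

Compound 3 (`CCC1(Cc2ccccc2)OS(=O)(=O)C=C1OCc1ccc(Cl)c(Cl)c1`), in an ADME assay on HEL cells (Homo sapiens) for cytotoxicity, with a stated time of 3 days (a lower number here means that less compound is tolerated, a higher number that more compound is tolerated), gives 36700 nM, the lowest of the two numbers shown. Its nearest neighbour is compound 2 (`CCC1(Cc2ccccc2)OS(=O)(=O)C=C1NCc1ccccc1`), which in this assay gives 92000 nM. Compound 1 (`CCC1(Cc2ccccc2)OS(=O)(=O)C=C1OCc1ccc(Cl)cc1`) reaches only a limit in this assay, > 200000 nM. Among the measured compounds shown here, the one step between measured compounds that differ in a single place runs from compound 1 to compound 3, where an at least 5.4-fold lower number from compound 1 to compound 3 (0.73 log units; beyond the scatter), and the larger chlorinated compound sat at the lower number; the starting point was the limit of > 200000 nM in this assay, at which 1 of the 3 values shown sits.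

Compound 4 (`C=CCOC1=CS(=O)(=O)OC1(CC)Cc1ccccc1`) is not yet measured. It differs from compound 3 in that (vinyl in place of 3,4-dichlorophenyl on a saturated chain carbon bound to an oxygen on an unsaturated carbon). This change removes the whole 3,4-dichlorophenyl that carried the chloro gained in the step from compound 1 to compound 3, so the bearing step points to a higher number for compound 4, and the size is at least as large as that step. Compound 4 is therefore expected to give about 150000 nM in this assay, within 40000 nM to 200000 nM, an estimated step of a 4.1-fold higher number from compound 3 to compound 4 (0.61 log units; beyond the scatter), and it may well end at the same limit as compound 1.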

Compound 4, half-maximal cytotoxic concentration: > 200000 nM
Compound 4 gave a limit, no number; the forecaster's own chance of this, stated with the estimate: 50%; at least 1.3-fold (0.12 log units) between middle value and limit.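

In this assay, replacing the whole 3,4-dichlorophenyl with vinyl on a saturated chain carbon bound to an oxygen on an unsaturated carbon gives an at least 5.4-fold higher number from compound 3 to compound 4 (0.73 log units; beyond the scatter), so the lower number of compound 3 does not extend to a compound with no aromatic ring at this place. The comparison with the benzylamino compound, with allyloxy in place of benzylamino on a double-bonded ring carbon, adds an at least 2.1-fold higher number from compound 2 to compound 4 (0.33 log units; beyond the scatter). The step joining compound 1 and compound 4 cannot be read, and more of the series now sits at one limit: the limit of > 200000 nM in this assay, at which 2 of the 4 values shown sit.

The compounds shown leave open whether a longer chain in place of vinyl would give a number in this assay rather than a limit. A plain benzyloxy group would show whether the number of compound 2 goes with its nitrogen or with its unchlorinated ring.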